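The source may hold more compounds than are shown below. What is called first, only, known or untested is meant among the compounds shown, and "the series" means these compounds.

Working notes on the series. In an assay on isolated protein for inhibition of histone acetyltransferase KAT2B (Homo sapiens), read by fluorescence, with a stated time of 15 min (a lower number here means a stronger inhibitor, a higher number a weaker inhibitor), compound 1 `CCn1sc(Cl)cc1=O` gives 3000 nM. Going by the values given here, compound 2 `COC(=O)CCn1sc(Cl)cc1=O` gives 1800 nM in this assay, and the change a 1.7-fold lower number from compound 1 to compound 2 (0.22 log units; within the scatter) is the only measured step; it is too small to count. Compound 3 `CCn1c(=O)cc(Cl)[s+]1[O-]` carries the same core as compound 4 `COC(=O)CCn1c(=O)cc(Cl)[s+]1[O-]`. For compound 3 this assay gives only a limit, > 10000 nM, so where compound 3 stands is not known beyond (the limit of > 10000 nM in this assay, at which 1 of the 3 values shown sits). The change to compound 4 is methoxycarbonyl in place of hydrogen on a saturated chain carbon, two bonds along the chain from an aromatic nitrogen, the same change as from compound 1 to compound 2. Given that change ran within the scatter, the step that the limit leaves unreadable from compound 3 to compound 4 is expected to stay within the scatter too, with the limit likely reported again. Compound 4 is estimated at 15000 nM, with a range from 5000 nM to 50000 nM.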

Compound 4, half-maximal inhibitory concentration: 5600 nM
Beside the measured number, compound 4's estimate is 2.7-fold (0.43 log units) above it; the measured number falls inside the stated range.
By their numbers in this assay, from the lowest: compounds 2, 1 and 4 (each within the scatter of the next, the first and the last beyond it). At a limit, above all of these: compound 3.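

With methoxycarbonyl in place of hydrogen, the core of compound 3 now has a measured number in this assay, and the change reads as an at least 1.7-fold lower number from compound 3 to compound 4 (0.25 log units; that floor lies within the scatter). On these data alone, compound 3 itself remains at a limit, > 10000 nM, so the true size of this step stays unknown. The same change now stands on two cores, and the two steps cannot be told apart: the same change on two cores in this assay, a 1.7-fold lower number (0.22 log units; within the scatter) from compound 1 to compound 2 and an at least 1.7-fold lower number (0.25 log units; that floor lies within the scatter) from compound 3 to compound 4; the limit leaves it open whether they differ

The compounds shown leave open whether a carboxylic acid or a longer chain in place of methoxycarbonyl, at this same position, would move the number beyond the scatter.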